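The source may hold more compounds than are shown below. What is called first, only, known or untested is meant among the compounds shown, and "the series" means these compounds.

Measured so far: compound 1 `C[C@H]1C[C@H]1C(=O)N1CC2CC(C1)N2` with 170 nM and compound 2 `C[C@@H]1C[C@H]1C(=O)N1CC2CC(C1)N2` with 14 nM.

Among the compounds with values here, compound 2 gives the lowest number of the two in an assay on CHO cells for displacement of a labelled ligand from Neuronal acetylcholine receptor; alpha3/alpha6/beta2/beta3 (Homo sapiens), read by scintillation counting; on this read-out lower numbers stand for stronger inhibition and higher numbers for weaker inhibition; the only neighbour is compound 1, and a 12-fold lower number from compound 1 to compound 2 (1.08 log units; beyond the scatter) rests on a single stereocentre, the cause being (the fact that one of compounds 1 and 2 is drawn with a defined configuration and the other without, at the place where they differ). Compound 3 `C[C@H]1C[C@@H]1C(=O)N1CC2CC(C1)N2` goes further: the two compounds have the same atoms and bonds; at least one stereo element is drawn with a configuration in one of them and without one in the other: 2 of 4 stereo elements differ; a stereocentre at a saturated ring carbon is drawn R in compound 2 and S in compound 3; a stereocentre at a saturated ring carbon is drawn R in compound 2 and S in compound 3. Within the data shown here, no measured pair shares this double inversion, so only the single-centre step from compound 1 to compound 2 bears on it, and it was large. Compound 3 is therefore expected to give a higher number, a 6.4-fold higher number from compound 2 to compound 3 (0.81 log units; beyond the scatter), with the estimate 90 nM and a range from 15 nM to 500 nM.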

Compound 3, inhibition constant: 310 nM
Compound 3: the middle estimate sits 3.4-fold (0.54 log units) below what was measured, within the range that was stated.
By their numbers in this assay, from the lowest: compound 2; then compounds 1 and 3 (each within the scatter of the next).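

The double inversion gives a 22-fold higher number from compound 2 to compound 3 (1.35 log units; beyond the scatter), so the low number of compound 2 does not survive a change at either saturated ring carbon alone or at both together. The second inversion adds nothing that can be read, with a 1.8-fold higher number from compound 1 to compound 3 (0.26 log units; within the scatter). In this assay, compound 2 therefore stands apart, while compound 1 and compound 3 cannot be told apart.

Still open, going by these compounds, is whether this dependence on configuration holds with an ethyl group or a carboxylic acid in place of the methyl group.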